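Chain length in the aryl chromone series

A few compounds are considered here, and "the series" means these few. Any claim that something is new, unique, unknown or untested is made for them only; others in the source may bear on it.

Measured so far in an assay on isolated protein (Cavia porcellus) with Sigma non-opioid intracellular receptor 1 (Homo sapiens) as the target, read by radioligand binding; on this read-out lower numbers stand for stronger inhibition and higher numbers for weaker inhibition:
compound 1 `COc1ccc(-c2cc(=O)c3cc(OCCCCCN4CCC(O)CC4)ccc3o2)cc1` gives 493 nM
compound 2 `COc1ccc(-c2cc(=O)c3cc(OCCCCCCN4CCC(O)CC4)ccc3o2)cc1` gives 254 nM
compound 3 `O=c1cc(-c2ccccc2)oc2cc(OCCCCCCN3CCC(O)CC3)ccc12` gives 45 nM

The change (4-hydroxypiperidin-1-yl)methyl in place of 4-hydroxypiperidin-1-yl on a saturated chain carbon, five bonds along the chain from an oxygen on an aromatic ring made the step of a 1.9-fold lower number from compound 1 to compound 2 (0.29 log units; within the scatter). Compound 3 has the lowest number of the three, and the difference between its core and the core of compound 1 is not broken down here. Compound 4 `O=c1cc(-c2ccccc2)oc2cc(OCCCCCCCN3CCC(O)CC3)ccc12` is not yet measured; it carries the same kind of change, ((4-hydroxypiperidin-1-yl)methyl in place of 4-hydroxypiperidin-1-yl on a saturated chain carbon, six bonds along the chain from an oxygen on an aromatic ring), with the place one bond further along the chain than in the pair of compound 1 and compound 2. Given the small step from compound 1 to compound 2, compound 4 is expected to sit near compound 3, with an estimated step of a 1.4-fold lower number from compound 3 to compound 4 (0.15 log units; within the scatter) in this assay. In this assay compound 4 is expected to give 32 nM, within a range from 12 nM to 85 nM.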

Compound 4, half-maximal inhibitory concentration: 16 nM
The estimate for compound 4 lay 2.0-fold (0.30 log units) above the measured number; the measured number falls inside the stated range.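

In this assay, (4-hydroxypiperidin-1-yl)methyl in place of 4-hydroxypiperidin-1-yl gives a 2.8-fold lower number from compound 3 to compound 4 (0.45 log units; beyond the scatter) on this second core. Set against the earlier pair, the change carries between these two cores with no difference that can be told from scatter: the same change on two cores in this assay, a 1.9-fold lower number (0.29 log units; within the scatter) from compound 1 to compound 2 and a 2.8-fold lower number (0.45 log units; beyond the scatter) from compound 3 to compound 4, 1.4-fold (0.16 log units) apart, within the scatter of two such steps

This rests on one pair per core, with the change at a different place along the chain in each, and does not show that the step would hold on a third core or further along the chain.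

Still open, from the compounds shown here alone, is whether a longer chain than that of compound 4 continues the trend on either core. Also open, going by these compounds, is whether another amine, such as morpholine or unsubstituted piperidine, in place of 4-hydroxypiperidin-1-yl follows the same steps.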